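Difluoromethyl in Place of Trifluoromethyl on a Second Core

The source may hold more compounds than are shown below. What is called first, only, known or untested is meant among the compounds shown, and "the series" means these compounds.

Compound 1 `CCC(=O)NS(=O)(=O)c1ccc(-n2nc(C(F)(F)F)cc2-c2ccc(Br)cc2)cc1COC(=O)CC` and compound 2 `CCC(=O)NS(=O)(=O)c1ccc(-n2nc(C(F)F)cc2-c2ccc(Br)cc2)cc1COC(=O)CC` share one core and differ in a single spot: hydrogen in place of fluoro on a saturated chain carbon bound to an aromatic carbon and two fluorine atoms. Among the compounds with values here, in a functional assay on the whole organism (strain Wistar) with Rattus norvegicus as the target, read by paw edema (on this read-out lower numbers stand for an effect already at smaller amounts and higher numbers for an effect only at larger amounts of compound), compound 1 gives 12.5 mg/kg, and compound 2 gives 7.9 mg/kg; the step of a 1.6-fold lower number from compound 1 to compound 2 (0.20 log units; within the scatter) is the only measured instance of this change. Compound 3 `CCC(=O)OCc1cc(-n2nc(C(F)(F)F)cc2-c2ccc(OC)c(C)c2)ccc1S(N)(=O)=O` carries a different core; the difference between the two cores is not broken down here. In this assay compound 3 gives 10.9 mg/kg. Compound 4 `CCC(=O)OCc1cc(-n2nc(C(F)F)cc2-c2ccc(OC)c(C)c2)ccc1S(N)(=O)=O` is derived from compound 3 by the same change, (hydrogen in place of fluoro on a saturated chain carbon bound to an aromatic carbon and two fluorine atoms), and has not been measured. Within the data shown here, the step expected for compound 4 is a 1.5-fold lower number from compound 3 to compound 4 (0.16 log units; within the scatter), because the one measured precedent, a 1.6-fold lower number from compound 1 to compound 2 (0.20 log units; within the scatter), stayed within the scatter. On that basis compound 4 is estimated at 7.5 mg/kg, between 4 mg/kg and 14 mg/kg.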

Compound 4, dose for half-maximal effect: 15 mg/kg
Compound 4: middle estimate off by 2.0-fold (0.30 log units), on the low side; the whole stated range lies below it.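

In this assay the change from trifluoromethyl to difluoromethyl gives a 1.4-fold higher number from compound 3 to compound 4 (0.14 log units; within the scatter), and the two steps now available do not differ beyond what repeated measurement allows: the same change on two cores in this assay, a 1.6-fold lower number (0.20 log units; within the scatter) from compound 1 to compound 2 and a 1.4-fold higher number (0.14 log units; within the scatter) from compound 3 to compound 4, 2.2-fold (0.34 log units) apart, within the scatter of two such steps. On these two cores, then, the change stays within the scatter, and nothing marks it as acting differently on one core than on the other. Two small steps do not show that the change has no effect, nor that it would behave alike on further cores.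

The compounds shown leave open how a methyl group or a nitrile would read in place of trifluoromethyl. Also open, going by these compounds, is whether the same change would stay this small on a core carrying a carboxylic acid.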